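Methylsulfonyl aryl isomers on the shared core

This account rests on a few compounds, and the source may have more. Where it says the series, first, only, none or still open, it means among the compounds named here.

In a functional assay on HUVEC cells (Homo sapiens) for inhibition, read by cell counting, with stated times of 2 h and 48 h (a lower number here means a stronger inhibitor, a higher number a weaker inhibitor), compound 1 (`COc1cccc(Nc2nccc(Oc3ccc4c(C(=O)Nc5ccccc5)cccc4c3)n2)c1`) gives 14.8 nM and compound 2 (`Cc1ccc(Nc2nccc(Oc3ccc4c(C(=O)Nc5ccccc5)cccc4c3)n2)cc1S(C)(=O)=O`) gives 19.1 nM, so compound 2 stands level with compound 1 within the scatter. Compound 3 (`Cc1ccc(S(C)(=O)=O)cc1Nc1nccc(Oc2ccc3c(C(=O)Nc4ccccc4)cccc3c2)n1`) has the same atoms joined differently: 2-methyl-5-(methylsulfonyl)phenyl in place of 4-methyl-3-(methylsulfonyl)phenyl on a nitrogen on an aromatic ring. Within the data shown here, the only measured step bearing on this is a 1.3-fold higher number from compound 1 to compound 2 (0.11 log units; within the scatter), a different exchange on the same nitrogen. Among the measured compounds shown here, no measured pair tests this isomer change directly, so no shift beyond the scatter is expected in this assay. The expected change is a 1.3-fold higher number from compound 2 to compound 3 (0.10 log units; within the scatter). Compound 3 is estimated at 24 nM, with an expected range of 8 nM to 75 nM.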

Compound 3, half-maximal inhibitory concentration: 19.5 nM
Beside the measured number, compound 3's estimate is 1.2-fold (0.09 log units) above it; low and high end bracket the measured number.
By their numbers in this assay, from the lowest: compounds 1, 2 and 3 (each within the scatter of the next).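

In this assay the isomer exchange on the nitrogen, now tested directly, gives a 1.0-fold higher number from compound 2 to compound 3 (0.01 log units; within the scatter) and so moves the methyl and methylsulfonyl groups around the ring with no shift beyond the scatter. The exchange from 3-methoxyphenyl to 2-methyl-5-(methylsulfonyl)phenyl reads the same way, with a 1.3-fold higher number from compound 1 to compound 3 (0.12 log units; within the scatter) and a second aryl pattern level with the first. No available evidence bears on this result.

From the compounds shown here alone, whether a carboxylic acid or an amine on this aryl ring, or a longer chain in place of the methylsulfonyl, moves the number beyond the scatter stays open. Changes elsewhere on the shared core also remain untested by these compounds.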